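The source may report more compounds than this note shows. Statements on the series, on what has been measured and on what is new or still open speak of the compounds shown alone.

Compound 3 `CCOc1nc2nc(C)cc(Nc3ccc(S(F)(F)(F)(F)F)cc3)n2n1` gives 97.7% in an ADME assay on a cell-free system (plasma, Homo sapiens) for protein binding, the lowest unbound fraction of the three measured compounds; compound 2 `Cc1cc(Nc2ccc(C(F)(F)F)cc2)n2nc(C3CC3)nc2n1` gives 92.8% and compound 1 `COCc1nc2nc(C)cc(Nc3ccc(C(F)(F)F)cc3)n2n1` gives 75.6%. Compound 4 `CCOc1nc2nc(C)cc(Nc3ccc(C(F)(F)F)cc3)n2n1` differs from compound 3 by a group of 4 heavy atoms (1 carbon, 3 fluorine; no ring) in place of a group of 6 heavy atoms (5 fluorine, 1 sulfur; no ring), on an aromatic carbon. Within the data shown here, the only measured step, a 3.4-fold lower unbound fraction from compound 1 to compound 2 (0.53 log units; beyond the scatter), changes a different part of the shared core and so does not bear on this exchange; no measured pair sets the sulfur-bearing group against trifluoromethyl. The step is therefore expected to be small, a 2.2-fold higher unbound fraction from compound 3 to compound 4 (0.34 log units; beyond the scatter), a modest rise in unbound fraction or nothing beyond the scatter. Compound 4 is estimated to give 95% in this assay, within a range of 86% to 98.5%.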

Compound 4, plasma protein binding: 92.4%
The estimate for compound 4 lay 1.5-fold (0.18 log units) (unbound fraction) below the measured number; the measured number falls inside the stated range.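

In this assay the step a 3.3-fold higher unbound fraction from compound 3 to compound 4 (0.52 log units; beyond the scatter) puts a measured size on trifluoromethyl in place of the sulfur-bearing group on this aromatic carbon. At the other varied place, the step a 3.2-fold lower unbound fraction from compound 1 to compound 4 (0.51 log units; beyond the scatter) sets ethoxy against methoxymethyl, while the step a 1.1-fold higher unbound fraction from compound 2 to compound 4 (0.02 log units; within the scatter) leaves ethoxy and cyclopropyl with no difference to read. Nothing measured here explains these steps. Going by these compounds, it stays open whether the trifluoromethyl exchange keeps its size with cyclopropyl or methoxymethyl in the other place. On these data alone, a nitrile on that aromatic carbon, or an amine in place of ethoxy, also remains unknown.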